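The source may hold more compounds than are shown below. What is called first, only, known or untested is meant among the compounds shown, and "the series" means these compounds.

Compound 1 `CCCCNc1nc(N)nc2c1CN(C(C)=O)CC2` gives 0.5 uM in an assay on HEK293 cells for agonist activity at Toll-like receptor 8 (Homo sapiens), read by a luciferase reporter, with a stated time of 6 h; a lower number here means that less compound is needed, a higher number that more compound is needed for the effect.
Compound 2 `CCCCNc1nc(N)nc2c1CN(Cc1ccccn1)CC2` gives 0.07 uM.
Compound 3 `CCCCNc1nc(N)nc2c1CN(Cc1ccncc1)CC2` gives 0.29 uM.

Compound 3 holds the second highest of the three numbers. Its nearest neighbour on the numbers is reached by a 1.7-fold lower number from compound 1 to compound 3 (0.24 log units; within the scatter), a step within the scatter, and the furthest by a 4.1-fold higher number from compound 2 to compound 3 (0.62 log units; beyond the scatter), a step beyond it. The pyridinylmethyl series thus spans a modest range, and only the pyridin-2-yl member of it, compound 2, sits clearly apart from the acetyl compound 1, a step given by a 7.1-fold lower number from compound 1 to compound 2 (0.85 log units; beyond the scatter).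

Compound 4 `CCCCNc1nc(N)nc2c1CN(C(=O)c1ccncc1)CC2` differs from compound 3 in one place: (pyridin-4-yl)carbonyl in place of (pyridin-4-yl)methyl on an amine nitrogen in a ring. Going by the values given here, the only measured step that bears on this change is the one in which acetyl gave way to the same (pyridin-4-yl)methyl, compound 1 to compound 3, and that step stayed within the scatter. Compound 4 restores a carbonyl on the ring nitrogen while keeping the pyridin-4-yl, so it is expected to land between compound 1 and compound 3, with the step of a 1.4-fold higher number from compound 3 to compound 4 (0.14 log units; within the scatter) expected to stay within the scatter. Compound 4 is therefore estimated at 0.4 uM, with a range of 0.15 uM to 1.2 uM.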

Compound 4, minimum effective concentration: > 25 uM
Compound 4: only a limit was reported (the forecaster's own chance of this, stated with the estimate: 5%); middle value at least 62-fold (1.79 log units) from the limit.
By their numbers in this assay, from the lowest: compound 2; then compounds 3 and 1 (each within the scatter of the next). At a limit, above all of these: compound 4.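

Compound 4 stands only at a limit, the single one of the series to do so: the limit of > 25 uM in this assay, at which 1 of the 4 values shown sits.

The earlier swap of acetyl for (pyridin-4-yl)methyl stayed within the scatter, so that position looked forgiving, yet with pyridin-4-yl kept, carbonyl in place of methyl on the amine nitrogen in a ring gives an at least 86-fold higher number from compound 3 to compound 4 (1.93 log units; beyond the scatter). What sits on the carbonyl carbon also counts, since pyridin-4-yl in place of methyl there gives an at least 50-fold higher number from compound 1 to compound 4 (1.69 log units; beyond the scatter), and the step that also moves the ring nitrogen of the pyridine, an at least 350-fold higher number from compound 2 to compound 4 (2.55 log units; beyond the scatter), is large as well.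

Still open, going by these compounds, is whether the loss goes with any ring on the carbonyl or with pyridin-4-yl in particular. A (pyridin-2-yl)carbonyl, a benzoyl or a longer acyl chain such as butanoyl on the same nitrogen would separate these readings.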